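The source may report more compounds than this note shows. Statements on the series, on what has been measured and on what is new or still open speak of the compounds shown alone.

Series notes. The shared core carries a methylpiperazine and varies only in the two substituents on the carbocyclic ring. Compound 1 `Cc1cc(Cl)c2oc(N3CCN(C)CC3)nc2c1` gives 0.26 in an assay on ileum (strain Hartley) with 5-hydroxytryptamine receptor 3A (Cavia porcellus) as the target (a lower number here means a smaller maximal response, a higher number a larger maximal response), and compound 2 `CCc1cc(Cl)cc2nc(N3CCN(C)CC3)oc12` gives 0.17. Compound 3 `Cc1cc(C)c2oc(N3CCN(C)CC3)nc2c1`, the dimethyl member, gives 0.62, the highest of the three numbers; the gap to compound 1 and the gap to compound 2 both lie beyond the scatter.

Compound 4 `Cc1cc(Cl)cc2nc(N3CCN(C)CC3)oc12` is unmeasured. Relative to compound 3 the change is chloro in place of methyl on an aromatic carbon, so compound 4 is a positional isomer of compound 1 and carries the substitution pattern of compound 2 with methyl in place of ethyl. Going by the values given here, the one step that bears on this is a number 0.36 higher from compound 1 to compound 3 (beyond the scatter), the reverse exchange at the other carbon. Running it backwards, together with the low number of compound 2, a drop of comparable size is expected, giving a number 0.37 lower from compound 3 to compound 4 (beyond the scatter) in this assay. Compound 4 is therefore estimated at 0.25, with a range from 0.1 to 0.45.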

Compound 4, intrinsic activity: the largest response reached, as a fraction of the reference agonist's: 0.24
The estimate for compound 4 lay 0.010 above the measured number; low and high end bracket the measured number.
By their numbers in this assay, from the lowest: compounds 2, 4 and 1 (each within the scatter of the next); then compound 3.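

In this assay, chloro in place of methyl on this aromatic carbon, meta to a fused ring and para to a fused ring, gives a number 0.38 lower from compound 3 to compound 4 (beyond the scatter), so this position responds to the exchange as strongly as the other substituted carbon did in the earlier step. The neighbouring alkyl group matters far less with chloro in place: hydrogen in place of methyl on the saturated chain carbon bound to an aromatic carbon gives a number 0.070 higher from compound 2 to compound 4 (within the scatter), so ethyl and methyl cannot be told apart here. No measured evidence accounts for either step.

From the compounds shown here alone, whether a methoxy group or an amine on this carbon would bring the number nearer to that of compound 3 or of compound 4 remains open. Also open, going by these compounds, is whether a chain longer than ethyl would still leave the number within the scatter of compound 4.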